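The source may hold more compounds than are shown below. What is called first, only, known or untested is meant among the compounds shown, and "the series" means these compounds.

Working notes on the series.

Compound 1 `Brc1ccc(C(c2c[nH]c3ccc(Br)cc23)c2c[nH]c3ccc(Br)cc23)cc1` is the reference point. In a functional assay on MCF7 cells (Homo sapiens) for inhibition, read by MTT assay, with a stated time of 48 h (on this read-out higher numbers stand for weaker inhibition and lower numbers for stronger inhibition), compound 1 gives 3200 nM. Compound 2 `O=[N+]([O-])c1ccc(C(c2c[nH]c3ccc(Br)cc23)c2c[nH]c3ccc(Br)cc23)cc1` carries the change nitro in place of bromo on an aromatic carbon and in this assay compound 2 gives 3100 nM; the step of a 1.0-fold lower number from compound 1 to compound 2 (0.01 log units; within the scatter) is flat. Compound 3 `OC[C@H]1O[C@@H](n2cc(C(c3ccc(Br)cc3)c3cn([C@@H]4O[C@H](CO)[C@@H](O)[C@H](O)[C@H]4O)c4ccc(Br)cc34)c3cc(Br)ccc32)[C@H](O)[C@@H](O)[C@@H]1O` is built on a different core, and how the two cores differ is not broken down here. In this assay compound 3 gives 51100 nM, the highest of the three numbers, and its gap to compound 1 and to compound 2 lies beyond the scatter in both cases.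

Compound 4 `O=[N+]([O-])c1ccc(C(c2cn([C@@H]3O[C@H](CO)[C@@H](O)[C@H](O)[C@H]3O)c3ccc(Br)cc23)c2cn([C@@H]3O[C@H](CO)[C@@H](O)[C@H](O)[C@H]3O)c3ccc(Br)cc23)cc1` is not yet measured. It differs from compound 3 by nitro in place of bromo on an aromatic carbon, the same change already seen between compound 1 and compound 2, made at the same kind of place; the wording of the place is identical for both pairs. The expectation for compound 4 therefore rests on one measured pair only. Going by the values given here, because a 1.0-fold lower number from compound 1 to compound 2 (0.01 log units; within the scatter) stayed within the scatter, the step from compound 3 to compound 4 is expected to be equally small, about a 1.0-fold lower number from compound 3 to compound 4 (0.01 log units; within the scatter), with the understanding that the core of compound 3 may respond differently and that no second example on this core exists. On that basis compound 4 is estimated to give 50000 nM in this assay, with the expected range running from 20000 nM to 125000 nM.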

Compound 4, half-maximal inhibitory concentration: 66700 nM
Compound 4: middle estimate off by 1.3-fold (0.13 log units), on the low side; the range from low to high includes it.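

In this assay, nitro in place of bromo on an aromatic carbon gives a flat step on the core of compound 3, a 1.3-fold higher number from compound 3 to compound 4 (0.12 log units; within the scatter), as it did on the core of compound 1. Set side by side, the two steps do not differ: the same change on two cores in this assay, a 1.0-fold lower number (0.01 log units; within the scatter) from compound 1 to compound 2 and a 1.3-fold higher number (0.12 log units; within the scatter) from compound 3 to compound 4, 1.3-fold (0.13 log units) apart, within the scatter of two such steps

This shows that, for the two cores compared here, the change from 4-bromophenyl to 4-nitrophenyl carries from one core to the other without a step that can be told from the scatter, but it rests on one pair per core and does not show that the same would hold on a further core, nor does it explain why the number stays flat.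

The compounds shown leave open whether a group other than bromo or nitro at this place, such as an amine, a carboxylic acid or a longer chain, would move the number on either core, since both groups tested here give the same flat result. Also open, going by these compounds, is whether the step would remain flat with the nitro group at another place on the six-membered aromatic ring, or with the remaining bromo groups of compound 3 and compound 4 replaced.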